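Amide replacements in a metabotropic glutamate modulator series

A few compounds are considered here, and "the series" means these few. Any claim that something is new, unique, unknown or untested is made for them only; others in the source may bear on it.

Compound 1 `CC(C)CCNC(=O)c1ccc(C#Cc2ccccc2)nc1` gives 510 nM in a functional assay on BHK cells for positive allosteric modulation of metabotropic glutamate receptor 5 (Homo sapiens), read by FLIPR and calcium flux; a lower number here means that less compound is needed, a higher number that more compound is needed for the effect.
Compound 2 `O=C(NC1CCCCC1)c1ccc(C#Cc2ccccc2)nc1` gives 240 nM in this assay.
Compound 3 `O=C(c1ccc(C#Cc2ccccc2)nc1)N1CCCCC1` gives 280 nM in this assay.

Compound 3 stands second highest of the three numbers; its nearest neighbour is compound 2, with a 1.2-fold higher number from compound 2 to compound 3 (0.07 log units; within the scatter), and its furthest is compound 1, with a 1.8-fold lower number from compound 1 to compound 3 (0.26 log units; within the scatter). Both gaps fall within the scatter, so the three amides are not separated by these data.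

Compound 4 `O=C(c1ccc(C#Cc2ccccc2)nc1)N1CCSCC1` differs from compound 3 by thiomorpholin-4-yl in place of piperidin-1-yl on a carbonyl carbon. For the measured compounds named here, no measured step exchanges a ring atom inside the amine part; the steps that bear on the amide region, a 2.1-fold lower number from compound 1 to compound 2 (0.33 log units; beyond the scatter) and a 1.2-fold higher number from compound 2 to compound 3 (0.07 log units; within the scatter), were modest or within the scatter. A similarly small step is therefore expected, a 1.3-fold higher number from compound 3 to compound 4 (0.10 log units; within the scatter), with no clear direction. Compound 4 is estimated at 350 nM in this assay, within 150 nM to 800 nM.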

Compound 4, half-maximal effective concentration: 46 nM
Compound 4: the middle estimate sits 7.6-fold (0.88 log units) above what was measured; measured number below the stated range.
By their numbers in this assay, from the lowest: compound 4; then compounds 2, 3 and 1 (each within the scatter of the next, the first and the last beyond it).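

In this assay, the amine part on this carbonyl carbon proves sensitive to a single ring-atom exchange: thiomorpholin-4-yl in place of piperidin-1-yl gives a 6.1-fold lower number from compound 3 to compound 4 (0.78 log units; beyond the scatter). For the compounds shown here, the same group also stands clear of the cyclohexylamino and isopentylamino amides, with a 5.2-fold lower number from compound 2 to compound 4 (0.72 log units; beyond the scatter) and an 11-fold lower number from compound 1 to compound 4 (1.04 log units; beyond the scatter), so this place can move the number well beyond what the earlier steps showed. Nothing at hand explains the difference.

The compounds shown leave open whether the step depends on the sulfur atom itself, as opposed to morpholin-4-yl, with oxygen in its place, or the corresponding thiomorpholine sulfone.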